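Swapping the Hydroxyphenyl Group for a Cyclohexyl Ring

The source may report more compounds than this note shows. Statements on the series, on what has been measured and on what is new or still open speak of the compounds shown alone.

Of the compounds shown here, two sharing one core have been measured in an assay on Cortex for displacement of a labelled ligand from adenosine receptor A1 (Rattus norvegicus); on this read-out lower numbers stand for stronger inhibition and higher numbers for weaker inhibition. Compound 1 `CCCn1c(=O)n(C)c(=O)c2[nH]c(-c3ccc(O)cc3)nc21` carries a 4-hydroxyphenyl group and gives 2.54 nM, the lowest number of the two. Compound 2 `CCCn1c(=O)n(C)c(=O)c2[nH]c(-c3ccc(C#N)cc3)nc21` carries a cyanophenyl group in its place and gives 13.9 nM; the change from compound 1 to compound 2 is a 5.5-fold higher number from compound 1 to compound 2 (0.74 log units; beyond the scatter), a modest loss from replacing the hydroxy with cyano.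

Compound 3 `CCCn1c(=O)n(C)c(=O)c2[nH]c(C3CCCCC3)nc21` is not yet measured. Its difference from compound 1 is cyclohexyl in place of 4-hydroxyphenyl on an aromatic carbon. Going by the values given here, the only measured step, from compound 1 to compound 2, shows that altering the group at this place moves the number modestly; the present change is larger in kind, since an aromatic ring with a hydroxy becomes a saturated ring without donors or acceptors. A modest upward step is therefore expected, roughly a 2.4-fold higher number from compound 1 to compound 3 (0.37 log units; beyond the scatter). For compound 3 the estimate in this assay is 6 nM, with a range from 1.5 nM to 25 nM.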

Compound 3, inhibition constant: 1.81 nM
Compound 3: middle estimate off by 3.3-fold (0.52 log units), on the high side, and the stated range covers the measured number.
By their numbers in this assay, from the lowest: compounds 3 and 1 (each within the scatter of the next); then compound 2.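

In this assay the exchange of 4-hydroxyphenyl for cyclohexyl gives a 1.4-fold lower number from compound 1 to compound 3 (0.15 log units; within the scatter) and so leaves compound 1 and compound 3 indistinguishable on this read-out. The place on the aromatic carbon between two ring nitrogen atoms therefore accepts a non-aromatic ring of carbon only, with no hydrogen-bond donors or acceptors, and the number stays as low as that of compound 1. Nothing available explains why these two different groups read alike.

Still open, as far as these compounds go, is whether a smaller ring such as cyclopentyl, or an open chain such as butyl, would keep the number this low. From the compounds shown here alone, it is equally open how an amine or a carboxylic acid attached to the cyclohexyl ring would move it.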